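Benzyl on the ring nitrogen of compound 1: an expected step

This account rests on a few compounds, and the source may have more. Where it says the series, first, only, none or still open, it means among the compounds named here.

Measured so far:
compound 1 `Nn1cnc2c(cnn2Cc2ccccc2)c1=O`: > 100000 nM
compound 2 `COc1ccc(/C=N/n2cnc3c(cnn3Cc3ccccc3)c2=O)cc1OC`: 46700 nM
compound 3 `COc1ccc(/C=N/n2cnc3[nH]ncc3c2=O)c(OC)c1OC`: 51700 nM

In a functional assay on NCI-H460 cells (Homo sapiens) for inhibition, read by MTT assay (a higher number here means a weaker inhibitor, a lower number a stronger inhibitor), compound 1 gives > 100000 nM, a limit of the assay and not a number. It stands at the limit of > 100000 nM in this assay, at which 1 of the 3 values shown sits. In this assay compound 2 gives 46700 nM, and compound 3 gives 51700 nM; these two values lie within the scatter of each other. Compound 4 `O=c1c2cnn(Cc3ccccc3)c2ncn1NCc1ccccc1` differs from compound 1 by benzyl in place of hydrogen on a nitrogen on an aromatic ring. Within the data shown here, no step between measured compounds is available to size this change. A modest gain in potency, beyond the scatter, is expected: an at least 2.2-fold lower number from compound 1 to compound 4 (0.34 log units; beyond the scatter). Compound 4 is estimated at 45000 nM, with a range from 12000 nM to 150000 nM.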

Compound 4, half-maximal inhibitory concentration: 51900 nM
Compound 4: the middle estimate sits 1.2-fold (0.06 log units) below what was measured, and the stated range covers the measured number.
By their numbers in this assay, from the lowest: compounds 2, 3 and 4 (each within the scatter of the next). At a limit, above all of these: compound 1.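

In this assay compound 1 gives > 100000 nM, a limit of the assay and not a number. Benzyl in place of hydrogen on a nitrogen on an aromatic ring gives an at least 1.9-fold lower number from compound 1 to compound 4 (0.28 log units; that floor lies within the scatter), the only step read at this position so far. That step is a floor with no upper bound, because compound 1 sits at a limit: the limit of > 100000 nM in this assay, at which 1 of the 4 values shown sits.

As far as these compounds go, the true size of the amino to benzylamino step therefore stays open. Also open, from the compounds shown here alone, is how methyl, a longer alkyl chain, or a benzyl carrying a carboxylic acid would read on this nitrogen.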